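Hydroxy in place of chloro: expectation for compound 3

A few compounds are considered here, and "the series" means these few. Any claim that something is new, unique, unknown or untested is made for them only; others in the source may bear on it.

Compound 2 `Fc1ccccc1/C=C/c1ccc(Cl)cc1` gives 1600 nM in an assay on HepG2 cells for activation of nuclear factor erythroid 2-related factor 2 (Homo sapiens), read by a luciferase reporter, with a stated time of 5 h; a higher number here means that more compound is needed for the effect, a lower number that less compound is needed; compound 1 `Cc1ccc(/C=C/c2ccccc2F)cc1` gives 1400 nM, and the step of a 1.1-fold higher number from compound 1 to compound 2 (0.06 log units; within the scatter) lies within the scatter, so the two stand together. Compound 3 `Oc1ccc(/C=C/c2ccccc2F)cc1` carries the change (hydroxy in place of chloro on an aromatic carbon). Among the compounds with values here, only one measured step exists, a 1.1-fold higher number from compound 1 to compound 2 (0.06 log units; within the scatter), and it did not move the number; no measured step involves a hydroxy group, so it bears only loosely on the present change. With nothing pointing either way, no step beyond the scatter is expected, a 1.1-fold lower number from compound 2 to compound 3 (0.03 log units; within the scatter). Compound 3 is estimated at 1500 nM, with a range from 600 nM to 4000 nM.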

Compound 3, half-maximal effective concentration: 11400 nM
Estimate against measurement, compound 3: 7.6-fold (0.88 log units) below; the measured number lies above the stated range.
By their numbers in this assay, from the lowest: compounds 1 and 2 (each within the scatter of the next); then compound 3.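

In this assay this position proves not indifferent to its substituent: methyl and chloro stand together, but hydroxy gives a 7.1-fold higher number from compound 2 to compound 3 (0.85 log units; beyond the scatter) and an 8.1-fold higher number from compound 1 to compound 3 (0.91 log units; beyond the scatter) on the same core. Hydroxy is thus the first group here to move the number beyond the scatter, and it also adds the only hydrogen-bond donor and acceptor at this place. No measurement on the cause of the shift is at hand. Open, as far as these compounds go, is whether an amine or a methoxy group at this place would shift the number likewise, so the result cannot yet be assigned to the donor, the acceptor or the oxygen.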